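Swapping the amine substituent in a coumarin amide series

The compounds below may be only part of what the source reports. "The series", "measured", "known", "first", "only" and "open" are said of these compounds alone.

Measured so far:
- compound 1, `CC(=O)Oc1ccc(C(=O)Nc2cc3ccc(OCC4CCCN(C)C4)c(C)c3oc2=O)cc1CC=C(C)C`: 740 nM
- compound 2, `CC(C)=CCc1cc(C(=O)Nc2cc3ccc(OCCCNC(C)C)c(C)c3oc2=O)ccc1O`: 750 nM
- compound 3, `CC(C)=CCc1cc(C(=O)Nc2cc3ccc(OCCCN(C)C(C)(C)C)c(C)c3oc2=O)ccc1O`: 880 nM

All three numbers come from a functional assay on SK-BR-3 cells (Homo sapiens) for antiproliferative activity; a higher number here means a weaker inhibitor, a lower number a stronger inhibitor. Compound 2 differs from compound 1 and from compound 3 by less than the usual scatter of this assay, so the three compounds cannot be told apart on potency.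

Compound 4, `CC(C)=CCc1cc(C(=O)Nc2cc3ccc(OCCCN[C@H](C)c4ccccc4)c(C)c3oc2=O)ccc1O`, has not yet been measured. It differs from compound 2 in one place: 1-phenylethyl in place of isopropyl on an amine nitrogen. Going by the values given here, the only measured step that touches the same amine nitrogen is the one in which compound 3 arose from compound 2, and there the result was a 1.2-fold higher number from compound 2 to compound 3 (0.07 log units; within the scatter). That single step says that changing what sits on this nitrogen left this assay unmoved, but it covers a smaller group than the one entering here, so the expectation rests on thin ground. No step beyond the scatter is expected. The step from compound 2 to compound 4 is estimated as a 1.1-fold lower number from compound 2 to compound 4 (0.03 log units; within the scatter). Compound 4 is therefore expected to give about 700 nM, within a range from 300 nM to 1600 nM.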

Compound 4, half-maximal inhibitory concentration: 1000 nM
Beside the measured number, compound 4's estimate is 1.4-fold (0.15 log units) below it, and the stated range covers the measured number.
By their numbers in this assay, from the lowest: compounds 1, 2, 3 and 4 (each within the scatter of the next).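

Replacing isopropyl with the larger 1-phenylethyl, which brings a six-membered aromatic ring and a defined stereocentre to the amine nitrogen, gives a 1.3-fold higher number from compound 2 to compound 4 (0.12 log units; within the scatter) in this assay, so this step stays within the scatter even with 8 heavy atoms entering in place of 3. The comparison with the tertiary amine of compound 3 gives a 1.1-fold higher number from compound 3 to compound 4 (0.06 log units; within the scatter) and is also within the scatter, so all the groups shown on this nitrogen, including one with an aromatic ring, give numbers that cannot be told apart. Nothing available here offers an explanation for this flat result.

The compounds shown leave open whether the opposite mirror-image form of 1-phenylethyl, or a benzyl or cyclohexyl group on this nitrogen, would also stay within the scatter. They also leave open whether a longer chain carrying this amine would move the number.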